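Ethyl ester versus free acid in a dibromo lactam series

The source may report more compounds than this note shows. Statements on the series, on what has been measured and on what is new or still open speak of the compounds shown alone.

Compound 1 `O=C(O)CC1CNC(=O)c2cc(Br)c(Br)n21` is the parent acid. In a functional assay on A549 cells (Homo sapiens) for cytotoxicity, read by CCK-8 assay, with a stated time of 72 h (on this read-out higher numbers stand for weaker inhibition and lower numbers for stronger inhibition), compound 1 gives only a limit, > 200000 nM. Compound 2 `CCOC(=O)CC1CNC(=O)c2cc(Br)c(Br)n21` carries ethyl in place of hydrogen on an oxygen next to a carbonyl group. In this assay compound 2 gives 41000 nM. That is an at least 4.8-fold lower number from compound 1 to compound 2 (0.68 log units; beyond the scatter). Compound 3 `O=C(O)CC1CNC(=O)c2ccc(Br)n21` differs from compound 1 by hydrogen in place of bromo on an aromatic carbon. In this assay compound 3 gives only a limit, > 200000 nM. The result is a step that the two limits leave unreadable from compound 1 to compound 3; two of the three values sit at the limit of > 200000 nM in this assay, at which 2 of the 3 values shown sit. Compound 4 `CCOC(=O)CC1CNC(=O)c2ccc(Br)n21` is not yet measured and stands to compound 3 as compound 2 stands to compound 1, with ethyl in place of hydrogen on an oxygen next to a carbonyl group, the same change at the same place. The expected step is an at least 3.3-fold lower number from compound 3 to compound 4 (0.52 log units; beyond the scatter), resting on an at least 4.8-fold lower number from compound 1 to compound 2 (0.68 log units; beyond the scatter), though the limit of compound 3 leaves its true size open. Compound 4 is expected at 60000 nM, between 25000 nM and 200000 nM.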

Compound 4, half-maximal inhibitory concentration: 32000 nM
Beside the measured number, compound 4's estimate is 1.9-fold (0.27 log units) above it, within the range that was stated.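

Ethyl in place of hydrogen on an oxygen next to a carbonyl group gives an at least 6.2-fold lower number from compound 3 to compound 4 (0.79 log units; beyond the scatter) in this assay, so the change carries over to the core with one bromo and lowers the number on both cores shown: the same change on two cores in this assay, an at least 4.8-fold lower number (0.68 log units; beyond the scatter) from compound 1 to compound 2 and an at least 6.2-fold lower number (0.79 log units; beyond the scatter) from compound 3 to compound 4; the limit leaves it open whether they differ

On the ethyl esters, hydrogen in place of bromo on an aromatic carbon gives a 1.3-fold lower number from compound 2 to compound 4 (0.11 log units; within the scatter).

The step between the two free acids cannot be read, and the exact size of the ester step on either core stays unknown, since compound 1 and compound 3 are both limits: the limit of > 200000 nM in this assay, at which 2 of the 4 values shown sit.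

The compounds shown leave open whether a longer chain on that oxygen, or an amide in place of the ester, behaves like ethyl. Also open, as far as these compounds go, is whether the change carries over to a core with an amine in place of the remaining bromo.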